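Halogen Substitution on the Sulfonyl Aryl in a Weakly Active Series

A few compounds are considered here, and "the series" means these few. Any claim that something is new, unique, unknown or untested is made for them only; others in the source may bear on it.

Going by the values given here, compound 2 `CC1(C)Oc2cc(NS(=O)(=O)c3ccccc3)ccc2NC1=O` carries a plain phenyl on the sulfonyl sulfur and stands at the high end of the three numbers known in a functional assay on PC-3 cells (Homo sapiens) for antiproliferative activity, read by luminescence, with a stated time of 96 h (a lower number here means a stronger inhibitor, a higher number a weaker inhibitor), where compound 2 gives 40100 nM. Its nearest neighbour is compound 1 `COc1ccc(Br)cc1S(=O)(=O)Nc1cc2c(cc1O)NC(=O)C(C)(C)O2`, which in this assay gives 22900 nM, and the furthest is compound 3 `COc1ccc(Br)cc1S(=O)(=O)Nc1ccc2c(c1)OC(C)(C)C(=O)N2`, which in this assay gives 21000 nM; both gaps to compound 2 lie within the scatter. Among the compounds with values here, the one measured step, a 1.1-fold lower number from compound 1 to compound 3 (0.04 log units; within the scatter), concerns hydrogen in place of hydroxy on the shared core and says nothing about the sulfonyl aryl. Compound 4 `CC1(C)Oc2cc(NS(=O)(=O)c3ccc(F)cc3Cl)ccc2NC1=O` differs from compound 2 by 2-chloro-4-fluorophenyl in place of phenyl on a sulfonyl sulfur. Within the data shown here, no measured step bears on this change; compounds 1 and 3, which carry a differently substituted aryl, sit within the scatter of compound 2. Compound 4 is therefore expected to show at most a small step, a 1.6-fold lower number from compound 2 to compound 4 (0.21 log units; within the scatter), towards a somewhat lower number. The estimate for compound 4 in this assay is 25000 nM, with a range from 8000 nM to 80000 nM.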

Compound 4, half-maximal inhibitory concentration: 27000 nM
Compound 4: the middle estimate sits 1.1-fold (0.03 log units) below what was measured, and the stated range covers the measured number.
By their numbers in this assay, from the lowest: compounds 3, 1, 4 and 2 (each within the scatter of the next).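

Going by these compounds alone, the step of a 1.5-fold lower number from compound 2 to compound 4 (0.17 log units; within the scatter) in this assay is the first measured change at the aryl group on the sulfonyl sulfur, and it stays within the scatter. With the shared core held constant, 2-chloro-4-fluorophenyl in place of phenyl therefore gives no readable gain or loss in this assay, even with two more heavy atoms on the aryl ring. Nothing measured here explains this outcome.

The compounds shown leave open whether chlorine or fluorine alone on the phenyl ring would give a similar result. They also leave open whether an amine or a carboxylic acid on that ring, or a longer chain in place of the aryl group, would move the number beyond the scatter.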